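The source may report more compounds than this note shows. Statements on the series, on what has been measured and on what is new or still open speak of the compounds shown alone.

In a functional assay on CCRF-CEM cells (Homo sapiens) (a higher number here means a weaker inhibitor, a lower number a stronger inhibitor), compound 2 `CCOc1ncnc2c1ncn2C[C@@H]1C[C@H](CO)c2ccccc21` gives 24 ug/mL, which puts it level with compound 1 `Nc1ncnc2c1ncn2C[C@@H]1C[C@H](CO)c2ccccc21` at 24 ug/mL. Compound 3 `COc1ncnc2c1ncn2C[C@@H]1C[C@H](CO)c2ccccc21` has not yet been measured. It differs from compound 2 by hydrogen in place of methyl on a saturated chain carbon bound to an oxygen on an aromatic ring, so that ethoxy becomes methoxy. Going by the values given here, only one measured step bears on this change, no change at the digits printed from compound 1 to compound 2 (within the scatter), where ethoxy replaced amino on an aromatic carbon. That replacement is a larger structural change than the one now in question, yet it left the value within the scatter. Among the compounds with values here, no measured step shortens the ethoxy chain itself, so this evidence is indirect. The step expected in this assay is therefore no change at the digits printed from compound 2 to compound 3 (within the scatter), with no direction favoured and nothing beyond the scatter. For compound 3 the expected value is 24 ug/mL, within an estimated range of 13 ug/mL to 45 ug/mL.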

Compound 3, half-maximal inhibitory concentration: 24 ug/mL
For compound 3 middle estimate and measured number coincide at the digits printed, within the range that was stated.
By their numbers in this assay, from the lowest: compounds 1, 2 and 3 (each within the scatter of the next).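

In this assay, going by these compounds alone, the shortening of ethoxy to methoxy gives no change at the digits printed from compound 2 to compound 3 (within the scatter) and so provides the first direct reading on this chain, which the earlier pair could not offer. Methoxy in place of amino gives no change at the digits printed from compound 1 to compound 3 (within the scatter) and so adds a second oxygen-linked group that stands level with the amino compound on this aromatic carbon. Nothing in the data at hand gives a reason for this flat result.

From the compounds shown here alone, whether the same holds for a longer chain such as butoxy, for a secondary amine such as methylamino, or for a chlorine atom on this carbon remains open. The three compounds also leave open whether any replacement here can move the read-out in either direction.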